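The compounds below may be only part of what the source reports. "The series", "measured", "known", "first", "only" and "open" are said of these compounds alone.

In a functional assay on HCT-116 cells (Homo sapiens), read by MTT assay, with a stated time of 72 h (on this read-out lower numbers stand for stronger inhibition and higher numbers for weaker inhibition), compound 1 (`Cc1nc(N)c2c(-c3cccs3)cn([C@@H]3O[C@H](CO)[C@@H](O)[C@H]3O)c2n1`) gives only a limit (> 20000 nM) and no number. Compound 2 (`Cc1nc(N)c2c(-c3ccsc3)cn([C@@H]3O[C@H](CO)[C@@H](O)[C@H]3O)c2n1`) also gives only a limit (> 20000 nM) in this assay. Among the measured compounds shown here, compound 3 (`Cc1nc(N)c2c(-c3cc4ccccc4o3)cn([C@@H]3O[C@H](CO)[C@@H](O)[C@H]3O)c2n1`) gives 13100 nM and so holds the only true number of the three. Compound 4 (`C#Cc1cn([C@@H]2O[C@H](CO)[C@@H](O)[C@H]2O)c2nc(C)nc(N)c12`) carries ethynyl in place of 1-benzofuran-2-yl on an aromatic carbon. The steps of an at least 1.5-fold lower number from compound 1 to compound 3 (0.18 log units; that floor lies within the scatter) and an at least 1.5-fold lower number from compound 2 to compound 3 (0.18 log units; that floor lies within the scatter) bear on this change, and both floors lie within the scatter. The step that the two limits leave unreadable from compound 1 to compound 2 cannot be read. None of these steps involves ethynyl, so no step beyond the scatter is expected in this assay, and no direction can be assigned. The estimate means a 1.3-fold lower number from compound 3 to compound 4 (0.12 log units; within the scatter) as the expected step. Expected for compound 4 is 10000 nM with an estimated range from 1000 nM to 40000 nM as its bounds.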

Compound 4, half-maximal inhibitory concentration: > 20000 nM
Compound 4: no number, only a limit; the forecaster's own chance of this, stated with the estimate: 35%; middle value at least 2.0-fold (0.30 log units) from the limit.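

In this assay, compound 4 gives only a limit, > 20000 nM. Ethynyl on this aromatic carbon thus sits with thiophen-2-yl and thiophen-3-yl at the limit, with an at least 1.5-fold higher number from compound 3 to compound 4 (0.18 log units; that floor lies within the scatter), while the steps from compound 1 and from compound 2 to compound 4 cannot be read. Among these four compounds, only 1-benzofuran-2-yl gives a true number at this position, and the rest share one limit: the limit of > 20000 nM in this assay, at which 3 of the 4 values shown sit.

As far as these compounds go, how compound 1, compound 2 and compound 4 rank among themselves stays open. Also open, from the compounds shown here alone, is whether an amine or a longer alkyl chain on this carbon would give a true number.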